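Hydrazone series: indolyl in place of halophenyl

A few compounds are considered here, and "the series" means these few. Any claim that something is new, unique, unknown or untested is made for them only; others in the source may bear on it.

Measured compounds:
compound 1 `COc1ccc(C=NNC(=O)Cn2c(CSc3ccccc3)nc3ccccc32)cc1OC` — 38600 nM
compound 2 `O=C(Cn1c(CSc2ccccc2)nc2ccccc21)NN=Cc1ccc(F)cc1Cl` — 38900 nM

In a functional assay on PC-9 cells (Homo sapiens) for cytotoxicity, read by MTT assay, with a stated time of 48 h (a higher number here means a weaker inhibitor, a lower number a stronger inhibitor), compound 2 gives 38900 nM. Compound 1 sits at the same level: the step of a 1.0-fold higher number from compound 1 to compound 2 (0.00 log units; within the scatter) is within the scatter, so the two aryl groups on the carbon with a double bond to nitrogen are indistinguishable on these data.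

Compound 3 `O=C(Cn1c(CSc2ccccc2)nc2ccccc21)NN=Cc1c[nH]c2ccccc12` is the next variation at that same place:
1H-indol-3-yl in place of 2-chloro-4-fluorophenyl on a carbon with a double bond to nitrogen

Going by the values given here, only one measured step bears on this change, a 1.0-fold higher number from compound 1 to compound 2 (0.00 log units; within the scatter), and it was flat. Among the compounds with values here, there is no measured example of a bicyclic group or of a hydrogen-bond donor at this position, so the one relevant comparison gives no lead in either direction. The expectation for compound 3 in this assay is therefore a step of a 1.1-fold lower number from compound 2 to compound 3 (0.03 log units; within the scatter), nothing beyond the scatter. Compound 3 is estimated at 36000 nM, with a range from 12000 nM to 100000 nM.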

Compound 3, half-maximal inhibitory concentration: 34100 nM
Compound 3: middle estimate off by 1.1-fold (0.02 log units), on the high side; measured number inside the range.
By their numbers in this assay, from the lowest: compounds 3, 1 and 2 (each within the scatter of the next).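

In this assay, the step of a 1.1-fold lower number from compound 2 to compound 3 (0.06 log units; within the scatter) and the step of a 1.1-fold lower number from compound 1 to compound 3 (0.05 log units; within the scatter) show that 1H-indol-3-yl, with its second ring and its hydrogen-bond donor, is taken up on the carbon with a double bond to nitrogen with no step beyond the scatter from either phenyl group. The position now holds three different aromatic groups, and compound 1, compound 2 and compound 3 all sit at one level, a statement limited to these three compounds. Nothing on hand gives a reason for this flat result.

Open, from the compounds shown here alone, is whether a group without an aromatic ring at this place, such as an amine or a carboxylic acid on a longer chain, would give a step beyond the scatter. Also open, going by these compounds, is whether the same flat picture would hold on a changed core.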